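This account rests on a few compounds, and the source may have more. Where it says the series, first, only, none or still open, it means among the compounds named here.

Series notes. Compound 1 `COc1ccc(N(C)c2nc(C)nc3ccccc23)cc1OCCN` is the anchor of the set. In a functional assay on A549 cells (Homo sapiens) for inhibition, read by MTT assay, with a stated time of 48 h (a lower number here means a stronger inhibitor, a higher number a weaker inhibitor), compound 1 gives 122 nM, the highest number among the three measured compounds. Compound 2 `C[Se]c1ccc(N(C)c2nc(C)nc3ccccc23)cc1C` gives 2 nM in this assay, and compound 3 `Cc1nc(N(C)c2ccc([Se]C#N)c(F)c2)c2ccccc2n1` gives 4 nM in this assay; both numbers lie well below that of compound 1, beyond the scatter, and both compounds carry selenium. Compound 4 `COc1ccc(N(C)c2nc(C)nc3ccccc23)cc1C[Se]C#N` has not yet been measured. It differs from compound 1 in one place: a group of 4 heavy atoms (2 carbon, 1 nitrogen, 1 selenium; no ring) in place of a group of 4 heavy atoms (2 carbon, 1 nitrogen, 1 oxygen; no ring), on an aromatic carbon. The entering group brings selenium into a compound that otherwise keeps the methoxy group of compound 1. Among the compounds with values here, no measured pair gives the size of such a step directly. The expectation is a downward step, a 12-fold lower number from compound 1 to compound 4 (1.09 log units; beyond the scatter), toward the region of compound 2 and compound 3, because compound 2 at 2 nM and compound 3 at 4 nM show that the selenium-bearing members of this set give low numbers. For compound 4 the estimate is 10 nM, with a range from 2 nM to 60 nM.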

Compound 4, half-maximal inhibitory concentration: 98 nM
For compound 4 the middle estimate is 9.8-fold (0.99 log units) below the measured one, outside the stated range (above it).
By their numbers in this assay, from the lowest: compounds 2 and 3 (each within the scatter of the next); then compounds 4 and 1 (each within the scatter of the next).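

In this assay the exchange of the 2-aminoethoxy group for the selenium-bearing group gives a 1.2-fold lower number from compound 1 to compound 4 (0.10 log units; within the scatter), so on this aromatic carbon, ortho to a methoxy group, the two groups are not told apart. Selenium in the entering group is therefore not enough on its own to give a low number at this position with the methoxy group kept, and compound 4 goes against any reading that all selenium-bearing members of the set give low numbers. Nothing available explains why these two groups read alike.

Open, as far as these compounds go, is whether another group on this aromatic carbon, such as a carboxylic acid or a longer chain, would shift the number. Also open, from the compounds shown here alone, is whether the same selenium-bearing group would read differently with the methoxy group replaced by a hydrogen or a fluorine.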